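Swapping Two Hydroxyls for Bromine on a Hydrazone Aryl Ring

This account rests on a few compounds, and the source may have more. Where it says the series, first, only, none or still open, it means among the compounds named here.

Compounds measured so far, in a physicochemical assay for lipophilicity, measured as octanol-water partition; on this read-out lower numbers stand for lower lipophilicity and higher numbers for higher lipophilicity:
Compound 1 `O=C(COc1cccc2ccccc12)N/N=C/c1ccc(O)cc1` gives 3.73
Compound 2 `O=C(COc1cccc2ccccc12)N/N=C/c1ccccc1Br` gives 4.81
Compound 3 `C/C(=N\NC(=O)COc1cccc2ccccc12)c1ccc(O)cc1O` gives 4.31

Compound 3 stands second highest of the three numbers. Its nearest neighbour is compound 2, which sits higher, and its furthest is compound 1, which sits lower; both gaps lie beyond the scatter.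

Compound 4 `C/C(=N\NC(=O)COc1cccc2ccccc12)c1ccc(Br)cc1` has not yet been measured in this assay. It differs from compound 3 in one place: 4-bromophenyl in place of 2,4-dihydroxyphenyl on a carbon with a double bond to nitrogen

Within the data shown here, one measured step bears on this change. Going from compound 1 to compound 2, a hydroxyphenyl was replaced by a bromophenyl on the same kind of carbon, and this assay moved a number 1.08 log units higher from compound 1 to compound 2 (beyond the scatter). The change from compound 3 to compound 4 goes the same way, and here two hydroxyl groups leave rather than one, so the step is expected to be at least as large and upward. Compound 2, with its bromophenyl, already sits above compound 3, which supports the direction.

The expected step is a number 1.19 log units higher from compound 3 to compound 4 (beyond the scatter), well beyond the scatter. Compound 4 is therefore estimated at 5.5, with a likely range from 4.9 to 6.1.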

Compound 4, partition coefficient: 3.61
Compound 4: the middle estimate sits 1.89 log units above what was measured; measured number below the stated range.
By their numbers in this assay, from the lowest: compounds 4 and 1 (each within the scatter of the next); then compound 3; then compound 2.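

In this assay, exchanging 2,4-dihydroxyphenyl for 4-bromophenyl on a carbon with a double bond to nitrogen gives a number 0.70 log units lower from compound 3 to compound 4 (beyond the scatter), which shows that replacing a hydroxylated ring with a brominated one at this place does not always push the number up. The earlier exchange gave a number 1.08 log units higher from compound 1 to compound 2 (beyond the scatter), so the two measured steps point in opposite directions and no single direction holds for this kind of change across the four compounds. Nothing available explains this reversal.

The two steps differ in more than one respect: the leaving ring carries one or two hydroxyl groups, the entering ring is 2-bromophenyl or 4-bromophenyl, and only compound 3 and compound 4 have a saturated chain carbon on the carbon with a double bond to nitrogen, so the compounds shown leave open which of these differences goes with the reversal. They also leave open how a ring carrying an amine or a carboxylic acid at the same place would read in this assay on either version of the core.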